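Pyridin-3-yl in place of a two-heteroatom ring

A few compounds are considered here, and "the series" means these few. Any claim that something is new, unique, unknown or untested is made for them only; others in the source may bear on it.

Measured compounds:
compound 1 `CC1=CC[C@H](C(=O)N(c2cc(C#CC(C)(C)C)sc2C(=O)O)[C@H]2CC[C@](O)(CO[C@H]3CCOC3)CC2)CC1` — 2.7 h
compound 2 `CC(C)(C)C#Cc1cc(N(C(=O)[C@H]2CC[C@H](C)CC2)[C@H]2CC[C@@](O)(CO[C@H]3CCOC3)CC2)c(C(=O)O)s1` — 0.2 h
compound 3 `CC(C)(C)C#Cc1cc(N(C(=O)[C@H]2CC[C@H](C)CC2)[C@H]2CC[C@@H](Oc3ccc(=O)[nH]n3)CC2)c(C(=O)O)s1` — 0.5 h

In an ADME assay on the whole organism (strain Sprague-Dawley) with Rattus norvegicus as the target, at a dose of 0.5 mg/kg by the intravenous route (a higher number here means that the compound lasts longer, a lower number that the compound disappears faster), compound 1 gives 2.7 h, compound 2 gives 0.2 h and compound 3 gives 0.5 h. Compound 3 thus stands second highest of the three numbers. Its nearest neighbour is compound 2, whose number is lower by more than the usual scatter; compound 1 lies further away, with a number higher by more than the scatter. Going by the values given here, none of the three pairs differs in only one place, so no single-change step in this assay can be read from them.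

Compound 4 `CC(C)(C)C#Cc1cc(N(C(=O)[C@H]2CC[C@H](C)CC2)[C@H]2CC[C@@H](Oc3cccnc3)CC2)c(C(=O)O)s1` differs from compound 3 in one place: a group of 6 heavy atoms (5 carbon, 1 nitrogen; one six-membered aromatic ring with 1 hetero atom) in place of a group of 7 heavy atoms (4 carbon, 2 nitrogen, 1 oxygen; one six-membered aromatic ring with 2 hetero atoms), on an oxygen on a saturated carbon. Among the compounds with values here, no measured pair shows a change of this kind, so the comparison rests on compound 3 alone. The step of a 1.2-fold higher number from compound 3 to compound 4 (0.08 log units; within the scatter) is expected to be small, with no direction beyond the scatter. Compound 4 is therefore expected to give about 0.6 h in this assay, within a range from 0.25 h to 1.5 h.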

Compound 4, mean residence time: 0.2 h
Beside the measured number, compound 4's estimate is 3.0-fold (0.48 log units) above it; the measured number lies below the stated range.
By their numbers in this assay, from the lowest: compounds 2 and 4 (each within the scatter of the next); then compound 3; then compound 1.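

At the oxygen on a saturated carbon, the attached ring matters in this assay: pyridin-3-yl in place of the ring with two hetero atoms gives a 2.5-fold lower number from compound 3 to compound 4 (0.40 log units; beyond the scatter), the only single-change step among the compounds shown. The group that leaves carries a hydrogen-bond donor and a double bond outside aromatic rings, whereas pyridin-3-yl has no such donor, but this one pair cannot separate these differences. Nothing available here bears on the reason for this step.

Going by these compounds, it remains open how a phenyl ring, a pyridin-2-yl group or a saturated ring carrying an amine would stand at this place in this assay. Also open, on these data alone, is whether the same exchange would give a step of similar size with a different amide group on the shared core.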